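Naphthalen-2-yl in Place of Thiophen-2-yl on the Hydrazone Carbon

The source may report more compounds than this note shows. Statements on the series, on what has been measured and on what is new or still open speak of the compounds shown alone.

In a functional assay on ECa-109 cells (Homo sapiens) for antiproliferative activity, read by MTT assay, with a stated time of 72 h (on this read-out lower numbers stand for stronger inhibition and higher numbers for weaker inhibition), three compounds have been measured so far:

Compound 1 `CCCSc1nc(N/N=C(\C)c2ccc(O)cc2)c2nnn(Cc3ccccc3)c2n1`: 32500 nM
Compound 2 `CCCSc1nc(N/N=C/c2cccs2)c2nnn(Cc3ccccc3)c2n1`: > 64000 nM
Compound 3 `CCCSc1nc(N/N=C(\C)c2ccccc2)c2nnn(Cc3ccccc3)c2n1`: 32200 nM

The value of compound 2 is a limit of the assay, not a number. Compound 4 `CCCSc1nc(N/N=C/c2ccc3ccccc3c2)c2nnn(Cc3ccccc3)c2n1` differs from compound 2 by naphthalen-2-yl in place of thiophen-2-yl on a carbon with a double bond to nitrogen. Among the measured compounds shown here, two measured steps bear on this change: an at least 1.9-fold lower number from compound 2 to compound 3 (0.29 log units; that floor lies within the scatter), and in the opposite direction an at least 1.9-fold higher number from compound 1 to compound 2 (0.29 log units; that floor lies within the scatter). Both are floors that lie within the scatter, so they point only weakly downward. Compound 4 is therefore expected to come off the limit and land near 32000 nM, with a range from 10000 nM to 100000 nM. For compound 4 this estimate means a step of an at least 2.0-fold lower number from compound 2 to compound 4 (0.30 log units; that floor lies within the scatter).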

Compound 4, half-maximal inhibitory concentration: > 64000 nM
Compound 4 was reported as a limit (the forecaster's own chance of this, stated with the estimate: 35%); at least 2.0-fold (0.30 log units) between middle value and limit.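

The step from compound 2 to compound 4 cannot be read, because both compounds sit at the same limit in this assay: the limit of > 64000 nM in this assay, at which 2 of the 4 values shown sit.

Going by these compounds, whether naphthalen-2-yl and thiophen-2-yl differ at all on a carbon with a double bond to nitrogen stays open.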